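The compounds below may be only part of what the source reports. "The series", "measured", "known", "first", "only" and "open" are said of these compounds alone.

Compound 3 `Cc1ccc(S(=O)(=O)c2cnc3cc(F)ccc3c2N2CCC(C)CC2)cc1Cl` carries a 3-chloro-4-methylphenyl group on its sulfonyl sulfur. In an assay on isolated protein for displacement of a labelled ligand from metabotropic glutamate receptor 5 (Homo sapiens), with a stated time of 60 min, tested at 1 uM (on this read-out lower numbers stand for less inhibition and higher numbers for more inhibition at the one concentration tested (going by the name of the read-out)), compound 3 gives 93%. Compound 1 `COc1ccc(S(=O)(=O)c2cnc3ccc(C)cc3c2N2CCC(C)CC2)cc1Cl` gives 93% in this assay, level with compound 3 within the scatter; together they are the highest of the three. Compound 2 `CC1CCN(c2c(S(=O)(=O)c3ccccc3)cnc3c(F)cccc23)CC1` gives 13% in this assay, far below compound 3 and beyond the scatter. Compound 4 `CC1CCN(c2c(S(=O)(=O)c3cc(Cl)cc(Cl)c3)cnc3cc(F)ccc23)CC1` has not yet been measured. The change is 3,5-dichlorophenyl in place of 3-chloro-4-methylphenyl on a sulfonyl sulfur. In both compound 1 and compound 3 the group on the sulfonyl sulfur holds a chlorine, and both give high numbers. A chlorine is kept in compound 4, so the expected step is a number 8 percentage points lower from compound 3 to compound 4 (within the scatter), likely none beyond the scatter or a slight fall. Compound 4 is estimated at 85%, between 60% and 97%.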

Compound 4, a percentage reported as inhibition, at one concentration (the size of the read-out at that concentration, not a potency): 87%
Estimate against measurement, compound 4: 2 percentage points below; low and high end bracket the measured number.
By their numbers in this assay, from the lowest: compound 2; then compounds 4, 1 and 3 (each within the scatter of the next).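

For the compounds shown here, compounds 3 and 4 give the first comparison in which only one place changes. In this assay, 3,5-dichlorophenyl in place of 3-chloro-4-methylphenyl on a sulfonyl sulfur gives a number 6 percentage points lower from compound 3 to compound 4 (within the scatter) on an otherwise unchanged structure. The ring on the sulfur can therefore carry a second chlorine instead of the methyl with no step beyond the scatter, though nothing measured here explains this.

From the compounds shown here alone, how a 3-aminophenyl or 3-carboxyphenyl group would read at this place remains open. So does whether a ring with no chlorine keeps the number high on this same core.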